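The source may hold more compounds than are shown below. What is called first, only, known or untested is meant among the compounds shown, and "the series" means these compounds.

Measured in a physicochemical assay for solubility, using the shake flask method, measured as kinetic solubility, with a stated time of 20 h, at pH 2; on this read-out higher numbers stand for higher solubility and lower numbers for lower solubility:
Compound 1 `FC(F)(F)Oc1ccc(-c2nc3cnc(Nc4ccccn4)cc3[nH]2)cc1`: 26000 nM
Compound 2 `COc1cccc(Nc2cc3[nH]c(-c4cccc(C(F)(F)F)c4)nc3cn2)n1`: 85000 nM
Compound 3 `COc1cccnc1Nc1cc2[nH]c(-c3cccc(C(F)(F)F)c3)nc2cn1`: 116000 nM

Compound 3, at 116000 nM, stands within the scatter of compound 2 and clearly higher than compound 1. Compound 4 `COc1ccc(Nc2cc3[nH]c(-c4cccc(C(F)(F)F)c4)nc3cn2)nc1`, not yet measured, has the same atoms as compound 3, joined differently: 5-methoxypyridin-2-yl in place of 3-methoxypyridin-2-yl on a nitrogen on an aromatic ring. In words, 5-methoxypyridin-2-yl takes the place of 3-methoxypyridin-2-yl on a nitrogen on an aromatic ring. Among the measured compounds shown here, one measured step bears on this, an exchange of 6-methoxypyridin-2-yl for 3-methoxypyridin-2-yl, which gave a 1.4-fold higher number from compound 2 to compound 3 (0.14 log units; within the scatter). For the measured compounds named here, no measured compound carries the 5-methoxypyridin-2-yl group. Going by the values given here, with only that small step as a guide, no change beyond the scatter is expected in this assay, and neither direction is favoured. The expected step is a 1.2-fold lower number from compound 3 to compound 4 (0.09 log units; within the scatter). Compound 4 is estimated at 95000 nM, with an expected range of 45000 nM to 190000 nM.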

Compound 4, solubility: < 5000 nM
Compound 4: no number, only a limit; the forecaster's own chance of this, stated with the estimate: 5%; at least 19-fold (1.27 log units) between middle value and limit.
By their numbers in this assay, from the lowest: compound 1; then compounds 2 and 3 (each within the scatter of the next). At a limit, below all of these: compound 4.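

Among the compounds shown here, the 3-methoxypyridin-2-yl and 6-methoxypyridin-2-yl groups had given values within the scatter of each other, so the earlier compounds gave no sign that the place of the methoxy group on this ring mattered. With 5-methoxypyridin-2-yl on the same nitrogen, an at least 23-fold lower number from compound 3 to compound 4 (1.36 log units; beyond the scatter) and an at least 17-fold lower number from compound 2 to compound 4 (1.23 log units; beyond the scatter) are both large steps in this assay and show that it can. Compound 4 has only a limit, not a number: the limit of < 5000 nM in this assay, at which 1 of the 4 values shown sits. The compounds shown leave open whether an ethoxy group, a hydroxyl group or an amine in place of the methoxy group of the 5-methoxypyridin-2-yl group would also end at this limit.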